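A few compounds are considered here, and "the series" means these few. Any claim that something is new, unique, unknown or untested is made for them only; others in the source may bear on it.

Compound 1 `N#CC1=C(N)Oc2c(c3nc4ccccc4nc3c3ccccc23)C12C(=O)N(Cc1cnnn1-c1ccc(Cl)cc1)c1ccccc12`: in a functional assay on A549 cells (Homo sapiens) for antiproliferative activity, read by MTT assay, with a stated time of 48 h (a higher number here means a weaker inhibitor, a lower number a stronger inhibitor), compound 1 gives > 50000 nM, which is a limit of the assay and not a number.
Compound 2 `Cc1ccc(-n2nncc2CN2C(=O)C3(C(C#N)=C(N)Oc4c3c3nc5ccccc5nc3c3ccccc43)c3ccccc32)c(C)c1`: compound 2 gives > 50000 nM, likewise a limit rather than a number.
Compound 3 `Cc1cccc(-n2nncc2CN2C(=O)C3(C(C#N)=C(N)Oc4c(N)cc5nc6ccccc6nc5c43)c3ccccc32)c1`: compound 3 gives 12300 nM.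

For the measured compounds named here, compound 3 thus holds the only number among the three; the other two sit at the limit of > 50000 nM in this assay, at which 2 of the 3 values shown sit. Compound 4 `N#CC1=C(N)Oc2c(N)cc3nc4ccccc4nc3c2C12C(=O)N(Cc1cnnn1-c1cccc(C(F)(F)F)c1)c1ccccc12` differs from compound 3 by trifluoromethyl in place of methyl on an aromatic carbon. Going by the values given here, the single computed step, a step that the two limits leave unreadable from compound 1 to compound 2, concerns a different change at a different place, and its two limits leave its size unreadable, so no measured step speaks to a methyl exchanged for a trifluoromethyl. With nothing pointing either way, the step is expected to be no change at the digits printed from compound 3 to compound 4 (within the scatter), none beyond the scatter. Compound 4 is therefore estimated at 12300 nM, with a range from 4000 nM to 40000 nM.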

Compound 4, half-maximal inhibitory concentration: 5400 nM
For compound 4 the middle estimate is 2.3-fold (0.36 log units) above the measured one, within the range that was stated.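

In this assay, trifluoromethyl in place of methyl on this aromatic ring gives a 2.3-fold lower number from compound 3 to compound 4 (0.36 log units; beyond the scatter), the first readable step among the compounds shown. This place on the ring therefore responds to a change of group, at least for this one exchange on the core of compound 3. The values shown give no reason for the shift.

On these data alone, whether a methoxy group or an amine at this place would move the number further remains open. So does whether the same exchange would act alike on the core of compound 1.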